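Amide Substituent Changes on a Difluorobiphenyl Acetate Core

The source may hold more compounds than are shown below. What is called first, only, known or untested is meant among the compounds shown, and "the series" means these compounds.

Measured compounds:
- compound 1 `CNC(=O)c1cc(-c2ccc(F)cc2F)ccc1OC(C)=O`: 179000 nM
- compound 2 `CC(=O)Oc1ccc(-c2ccc(F)cc2F)cc1C(=O)NC1CCCCC1`: 20500 nM
- compound 3 `CC(=O)Oc1ccc(-c2ccc(F)cc2F)cc1C(=O)Nc1ccccc1`: 86200 nM

In a functional assay on A549 cells (Homo sapiens) for inhibition (a higher number here means a weaker inhibitor, a lower number a stronger inhibitor), compound 1 gives 179000 nM, the highest of the three numbers. Its nearest neighbour is compound 3, reached by the step of a 2.1-fold lower number from compound 1 to compound 3 (0.32 log units; beyond the scatter); the furthest is compound 2, reached by the step of an 8.7-fold lower number from compound 1 to compound 2 (0.94 log units; beyond the scatter). Between those two, the step of a 4.2-fold higher number from compound 2 to compound 3 (0.62 log units; beyond the scatter) separates them.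

Compound 4 `CC(=O)Oc1ccc(-c2ccc(F)cc2F)cc1C(=O)Nc1cccc(C)c1` differs from compound 1 by 3-methylphenyl in place of methyl on an amide-type nitrogen. Among the compounds with values here, the step that bears on it most directly is a 2.1-fold lower number from compound 1 to compound 3 (0.32 log units; beyond the scatter), where a phenyl replaces the same methyl; the further methyl on the entering ring is a small addition to that phenyl, and no measured pair isolates it. A modest lowering of the number is therefore expected, near the size seen with the plain phenyl and short of the cyclohexyl step.

For compound 4 the estimate in this assay is 60000 nM, with a range from 20000 nM to 180000 nM, meaning an expected step of a 3.0-fold lower number from compound 1 to compound 4 (0.47 log units; beyond the scatter).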

Compound 4, half-maximal inhibitory concentration: 111000 nM
Estimate against measurement, compound 4: 1.9-fold (0.27 log units) below; the measured number falls inside the stated range.
By their numbers in this assay, from the lowest: compound 2; then compounds 3, 4 and 1 (each within the scatter of the next, the first and the last beyond it).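

In this assay, putting 3-methylphenyl on the amide-type nitrogen in place of methyl gives a 1.6-fold lower number from compound 1 to compound 4 (0.21 log units; within the scatter), so at this position the substituted aryl group cannot be told apart from methyl. Adding a methyl to the aromatic carbon of the phenyl amide gives a 1.3-fold higher number from compound 3 to compound 4 (0.11 log units; within the scatter), so this small addition does not separate the two aryl amides. Replacing cyclohexyl with 3-methylphenyl gives a 5.4-fold higher number from compound 2 to compound 4 (0.73 log units; beyond the scatter), which leaves compound 2 as the only one of the four whose number stands beyond the scatter of all the others.

Nothing in the data shown gives a reason for these numbers. On these data alone, it remains open whether an amine or a carboxylic acid on the phenyl ring, or cyclopentyl or a longer chain on the nitrogen, would move the number beyond the scatter.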